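The source may hold more compounds than are shown below. What is called first, only, known or untested is meant among the compounds shown, and "the series" means these compounds.

For the measured compounds named here, in a functional assay on HFF cells (Homo sapiens) for cytotoxicity (a lower number here means that less compound is tolerated, a higher number that more compound is tolerated), compound 1 (`CCCSc1nc(N)nc2c1ncn2/C=C1/C[C@@H]1CO`) gives 283000 nM, while compound 2 (`Nc1nc(OCC2CC2)c2ncn(/C=C3/C[C@@H]3CO)c2n1`) gives 112000 nM, the lower of the two numbers so far. The next compound, compound 3 (`CCCCCOc1nc(N)nc2c1ncn2/C=C1/C[C@@H]1CO`), keeps the shared core but has butyl in place of cyclopropyl on a saturated chain carbon bound to an oxygen on an aromatic ring. Read one bond further out, cyclopropylmethoxy becomes pentyloxy. Going by the values given here, only one measured step bears on this, and only indirectly: a 2.5-fold lower number from compound 1 to compound 2 (0.40 log units; beyond the scatter). That step is modest and lies beyond the scatter, but it exchanges propylsulfanyl for cyclopropylmethoxy, so it is a different change from the one at hand. Among the compounds with values here, no measured pair shows what replacing cyclopropyl with butyl does here. The step from compound 1 therefore offers a guide to size, but not to direction. A modest step is expected in this assay, leaning tentatively toward a lower number, and a result within the scatter would not be surprising. The expected change is a 1.4-fold lower number from compound 2 to compound 3 (0.15 log units; within the scatter). For compound 3 the estimated value is 80000 nM, with an expected range from 30000 nM to 200000 nM.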

Compound 3, half-maximal cytotoxic concentration: 41900 nM
Beside the measured number, compound 3's estimate is 1.9-fold (0.28 log units) above it; low and high end bracket the measured number.
By their numbers in this assay, from the lowest: compound 3; then compound 2; then compound 1.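

In this assay, for the compounds shown here, butyl in place of cyclopropyl on a saturated chain carbon bound to an oxygen on an aromatic ring gives the first measured step for this change (a 2.7-fold lower number from compound 2 to compound 3 (0.43 log units; beyond the scatter)), showing that the number at this position responds to the change from the ringed group to the open chain. Pentyloxy in place of propylsulfanyl on an aromatic carbon gives the largest step among the three compounds (a 6.8-fold lower number from compound 1 to compound 3 (0.83 log units; beyond the scatter)), and with the earlier step (a 2.5-fold lower number from compound 1 to compound 2 (0.40 log units; beyond the scatter)) it places both oxygen-linked compounds lower than the sulfur-linked one, with none of the three going against that order. Nothing measured here accounts for these differences in tolerated concentration.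

The change from cyclopropyl to butyl both removes the ring and adds a carbon, so the compounds shown cannot separate the contribution of one from the other. From the compounds shown here alone, it also remains open whether the number keeps falling with a longer chain such as heptyloxy, or how an amine on an aromatic carbon in place of the pentyloxy would compare.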